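From naphthalen-1-yl to 4-chlorophenyl: an unmeasured change

The compounds below may be only part of what the source reports. "The series", "measured", "known", "first", "only" and "open" are said of these compounds alone.

Three compounds with the same core and the same (naphthalen-1-yl)methyl group have numbers in a functional assay on RS4-11 cells (Homo sapiens) for inhibition, read by CCK-8 assay, with a stated time of 48 h, tested at 20 uM; on this read-out lower numbers stand for less inhibition of growth and higher numbers for more inhibition of growth at the one concentration tested. Compound 1 `N#C/C(=C\c1ccccc1OS(=O)(=O)c1ccc([N+](=O)[O-])cc1)C(=O)Nc1nnc(Cc2cccc3ccccc23)s1` gives 58%, compound 2 `N#C/C(=C\c1ccccc1OS(=O)(=O)c1ccccc1[N+](=O)[O-])C(=O)Nc1nnc(Cc2cccc3ccccc23)s1` gives 66% and compound 3 `N#C/C(=C\c1ccccc1OS(=O)(=O)c1ccc(Cl)cc1)C(=O)Nc1nnc(Cc2cccc3ccccc23)s1` gives 68%. Compound 3 therefore cannot be separated from the other two, as the steps show: a number 10 percentage points higher from compound 1 to compound 3 (within the scatter) and a number 2 percentage points higher from compound 2 to compound 3 (within the scatter).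

Compound 4 `N#C/C(=C\c1ccccc1OS(=O)(=O)c1ccc(Cl)cc1)C(=O)Nc1nnc(Cc2ccc(Cl)cc2)s1` keeps the sulfonyl side of compound 3 and differs at the other end: 4-chlorophenyl in place of naphthalen-1-yl on a saturated chain carbon bound to an aromatic carbon. This places 4-chlorophenyl in place of naphthalen-1-yl on a saturated chain carbon bound to an aromatic carbon.

The two steps above and the remaining one, a number 8 percentage points higher from compound 1 to compound 2 (within the scatter), all concern the group on the sulfonyl sulfur. They bear on the new change only indirectly, since none of them touches this place. They show a flat read-out for changes on the sulfonyl side and say nothing about the other end. The expectation is therefore no step beyond the scatter, held with little confidence. The expected step is a number 6 percentage points lower from compound 3 to compound 4 (within the scatter). The estimate for compound 4 is 62%, with an expected range of 40% to 80%.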

Compound 4, percent growth inhibition at one concentration: 64%
Beside the measured number, compound 4's estimate is 2 percentage points below it; measured number inside the range.
By their numbers in this assay, from the lowest: compounds 1, 4, 2 and 3 (each within the scatter of the next).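

In this assay, within the data shown here, the change at this end gives a number 4 percentage points lower from compound 3 to compound 4 (within the scatter) and is the first reading at this place, since all earlier steps concern the group on the sulfonyl sulfur. With the 4-chlorophenyl group on the sulfonyl sulfur held constant, naphthalen-1-yl, with two six-membered aromatic rings of carbon only, can give way to 4-chlorophenyl, with one such ring, without a step beyond the scatter; this rests on a single pair and a single tested concentration, so it sets no trend for the position. No supporting data are available to explain why these two groups cannot be separated in this read-out.

Open, on these data alone, is whether the read-out stays unchanged when the saturated chain carbon carries a group of a different kind, such as an amine, a carboxylic acid or a longer chain in place of these aromatic groups. Also open, as far as these compounds go, is whether 4-chlorophenyl at this place gives a comparable reading when paired with the 2-nitrophenyl group of compound 2 or the 4-nitrophenyl group of compound 1 on the sulfonyl sulfur.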